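Saturated ring in place of fluorophenyl on the shared core

The source may report more compounds than this note shows. Statements on the series, on what has been measured and on what is new or still open speak of the compounds shown alone.

Among the measured compounds shown here, in an ADME assay on HepG2 cells (Homo sapiens) for cytotoxicity, read by luminescence, CellTiter-Glo and ATP content, with a stated time of 72 h (on this read-out higher numbers stand for an effect only at larger amounts of compound and lower numbers for an effect already at smaller amounts), compound 2 `COc1cccc(CNCCCNc2ccnc3cc(Cc4ccc(F)cc4)ccc23)c1O` gives 4780 nM, the highest of the two numbers measured so far; compound 1 `COc1cccc(CNCCCNc2ccnc3cc(-c4ccc(C(F)(F)F)cc4)ccc23)c1O` gives 2210 nM, and the step of a 2.2-fold higher number from compound 1 to compound 2 (0.34 log units; beyond the scatter) is the only one known. Compound 3 `COc1cccc(CNCCCNc2ccnc3cc(CC4CCCCC4)ccc23)c1O` differs from compound 2 by cyclohexyl in place of 4-fluorophenyl on a saturated chain carbon bound to an aromatic carbon. For the measured compounds named here, no measured step exchanges an aromatic ring for a non-aromatic one, and the single step known concerns a different pair of groups, so it gives only a rough guide: a small step, likely within the scatter, is expected in this assay. Compound 3 is therefore estimated at 5000 nM, between 2000 nM and 12000 nM, an expected step of a 1.0-fold higher number from compound 2 to compound 3 (0.02 log units; within the scatter).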

Compound 3, half-maximal effective concentration: 970 nM
Compound 3: middle estimate off by 5.2-fold (0.71 log units), on the high side, outside the stated range (below it).
By their numbers in this assay, from the lowest: compound 3; then compound 1; then compound 2.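

In this assay, exchanging the aromatic ring for a saturated one on this saturated chain carbon is not a neutral change: a 4.9-fold lower number from compound 2 to compound 3 (0.69 log units; beyond the scatter). The step to the cyclohexylmethyl group on an aromatic carbon runs the same way, a 2.3-fold lower number from compound 1 to compound 3 (0.36 log units; beyond the scatter), so, among these three compounds, the one without a second aromatic ring shows its effect at the smallest amounts. Nothing available explains this result. The compounds shown leave open whether a cyclopentyl ring, a piperidine or an unsubstituted phenyl at this place would behave like compound 3 or like compound 2.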